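Swapping the amide-linked ring in a furan-bearing pyrrole series

The compounds below may be only part of what the source reports. "The series", "measured", "known", "first", "only" and "open" are said of these compounds alone.

Measured so far:
compound 1 `O=C(Cn1c(-c2ccc3ccccc3c2)cc(-c2ccccc2)c1-c1ccco1)Nc1nc2ccccc2s1`: 38.3%
compound 2 `CCc1nnc(NC(=O)Cn2c(-c3ccc4ccccc4c3)cc(-c3ccccc3)c2-c2ccco2)s1`: 83.6%
compound 3 `O=C(Cn1c(-c2ccccc2)cc(-c2cccc3ccccc23)c1-c1ccco1)Nc1nc2ccccc2s1`: 68.8%

All three were tested in an ADME assay on HEK-293T cells (Homo sapiens) for cytotoxicity, read by MTT assay, with a stated time of 72 h, tested at 50 uM; a higher number here means more inhibition at the concentration tested (going by the name of the read-out), a lower number less inhibition. Compound 1 and compound 3 are built from the same atoms joined differently; how their two cores differ is not broken down here, and compound 3 gives the higher number. Compound 2 differs from compound 1 by one change, (5-ethyl-1,3,4-thiadiazol-2-yl in place of 1,3-benzothiazol-2-yl on an amide-type nitrogen), and this step a number 45.3 percentage points higher from compound 1 to compound 2 (beyond the scatter) is large.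

Compound 4 `CCc1nnc(NC(=O)Cn2c(-c3ccccc3)cc(-c3cccc4ccccc34)c2-c2ccco2)s1` is not yet measured. It carries the same change made on the core of compound 3: 5-ethyl-1,3,4-thiadiazol-2-yl in place of 1,3-benzothiazol-2-yl on an amide-type nitrogen. Because the same change gave a number 45.3 percentage points higher from compound 1 to compound 2 (beyond the scatter), a step of similar direction is expected from compound 3, though the read-out cannot pass its ceiling, so the step is estimated as a number 21.2 percentage points higher from compound 3 to compound 4 (beyond the scatter). Compound 4 is therefore expected to give 90%, estimated between 76% and 100%.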

Compound 4, a percentage reported as inhibition, at one concentration (the size of the read-out at that concentration, not a potency): 59.7%
Estimate against measurement, compound 4: 30.3 percentage points above; the whole stated range lies above it.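

On the core of compound 3, putting 5-ethyl-1,3,4-thiadiazol-2-yl in place of 1,3-benzothiazol-2-yl on an amide-type nitrogen gives, in this assay, a number 9.1 percentage points lower from compound 3 to compound 4 (within the scatter). The large step seen on the core of compound 1 therefore does not carry over to the core of compound 3, as the two steps show: the same change on two cores in this assay, a number 45.3 percentage points higher (beyond the scatter) from compound 1 to compound 2 and a number 9.1 percentage points lower (within the scatter) from compound 3 to compound 4, 54.4 percentage points apart, beyond the scatter of two such steps. This does not show which feature of the two cores sets the steps apart, and two cores give no rule for any other core in the series.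

Still open, as far as these compounds go, is how both cores respond to other groups at this amide-type nitrogen. A longer chain in place of the ethyl group, or a carboxylic acid there, would be one such test.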